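Dimethylpyrazolyl for Ethyl on the Chloro-Bearing Ring

The source may report more compounds than this note shows. Statements on the series, on what has been measured and on what is new or still open speak of the compounds shown alone.

Compound 1 `CN1CCN(CCCS(=O)(=O)c2ccc3nc(NC(=O)NC(=O)c4cc(-n5cccn5)ccc4Cl)sc3c2)CC1` in a physicochemical assay for lipophilicity (a higher number here means a more lipophilic compound, a lower number a more polar compound), gives 2.
Compound 2 `CCc1ccc(Cl)c(C(=O)NC(=O)Nc2nc3ccc(S(=O)(=O)CCCN4CCN(C)CC4)cc3s2)c1` in this assay gives 2.9.

Of the two measured compounds, compound 2 stands highest: the step of a number 0.90 log units higher from compound 1 to compound 2 (beyond the scatter) is the only one available. Compound 3 `Cc1cc(C)n(-c2ccc(Cl)c(C(=O)NC(=O)Nc3nc4ccc(S(=O)(=O)CCCN5CCN(C)CC5)cc4s3)c2)n1` is not yet measured. It differs from compound 2 in one place: 3,5-dimethyl-1H-pyrazol-1-yl in place of ethyl on an aromatic carbon. Within the data shown here, the one step that bears on this change runs the other way, from a pyrazol-1-yl to an ethyl, and was of modest size. Here a pyrazole ring returns, but with two methyls on it, which no measured pair covers, so the expected step from compound 2 to compound 3 is estimated to be small, a number 0.10 log units lower from compound 2 to compound 3 (within the scatter), and likely within the scatter. For compound 3 the expected value in this assay is 2.8, with a range from 2.2 to 3.4.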

Compound 3, distribution coefficient: 2.5
Compound 3: middle estimate off by 0.30 log units, on the high side; the range from low to high includes it.
By their numbers in this assay, from the lowest: compound 1; then compound 3; then compound 2.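

At this aromatic carbon, para to a chloro group, 3,5-dimethyl-1H-pyrazol-1-yl in place of ethyl gives in this assay a number 0.40 log units lower from compound 2 to compound 3 (beyond the scatter), so a pyrazole ring bearing two methyls does not match ethyl here. The same position also separates the two pyrazoles, with a number 0.50 log units higher from compound 1 to compound 3 (beyond the scatter), which shows that the methyls on the ring count in this read-out and that the ring alone does not set the number. No measured evidence accounts for either shift.

The compounds shown leave open whether a single methyl on the pyrazole ring would give part of this step, and how each of the two methyls contributes. They also leave open how an amine, a carboxylic acid or a longer alkyl chain at this carbon would compare with ethyl and the two pyrazoles.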